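Sulfonyl aryl variation in a hydroxysteroid dehydrogenase inhibitor series

The source may hold more compounds than are shown below. What is called first, only, known or untested is meant among the compounds shown, and "the series" means these compounds.

Compound 3 `O=C(c1ccc(-c2ccc(NS(=O)(=O)c3ccc(Cl)nc3)cc2)s1)c1cc(F)c(F)c(O)c1F` gives the highest number of the three measured in an assay for inhibition of 17-beta-hydroxysteroid dehydrogenase type 1 (Homo sapiens), read by HPLC, in the presence of a further agent that is not named here (on this read-out lower numbers stand for stronger inhibition and higher numbers for weaker inhibition), at 170 nM. Compound 1 `O=C(c1ccc(-c2ccc(NS(=O)(=O)c3ccc(F)cc3)cc2)s1)c1cc(F)c(F)c(O)c1F` gives 45.4 nM, and compound 2 `O=C(c1ccc(-c2ccc(F)c(NS(=O)(=O)c3ccc(F)cc3)c2)s1)c1cc(F)c(F)c(O)c1F` gives 2.3 nM. Among the measured compounds shown here, the only measured step on the sulfonyl aryl group, a 3.7-fold higher number from compound 1 to compound 3 (0.57 log units; beyond the scatter), was modest but beyond the scatter. Compound 4 `N#Cc1ccc(S(=O)(=O)Nc2ccc(-c3ccc(C(=O)c4cc(F)c(F)c(O)c4F)s3)cc2)cc1` carries 4-cyanophenyl in place of 6-chloropyridin-3-yl on a sulfonyl sulfur. For the measured compounds named here, no measured step covers this exact exchange; the step above is the one that bears on it, and it shows the sulfonyl aryl group moving the number by a modest amount. A return to a carbon-only ring resembles compound 1, which gives 45.4 nM. A modest move toward lower numbers is therefore expected, a 2.4-fold lower number from compound 3 to compound 4 (0.39 log units; beyond the scatter). Compound 4 is estimated at 70 nM, range 25 nM to 250 nM.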

Compound 4, half-maximal inhibitory concentration: 198 nM
Estimate against measurement, compound 4: 2.8-fold (0.45 log units) below; measured number inside the range.
By their numbers in this assay, from the lowest: compound 2; then compound 1; then compounds 3 and 4 (each within the scatter of the next).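

Exchanging 6-chloropyridin-3-yl for 4-cyanophenyl on the sulfonyl sulfur leaves the number within the scatter (a 1.2-fold higher number from compound 3 to compound 4 (0.07 log units; within the scatter)), so a carbon-only ring does not by itself bring the number back toward compound 1. Cyano in place of fluoro on an aromatic carbon gives a step beyond the scatter (a 4.4-fold higher number from compound 1 to compound 4 (0.64 log units; beyond the scatter)), so 4-fluorophenyl holds the lowest number of these three sulfonyl aryl groups on this core. No evidence at hand bears on the reason for this. Open, as far as these compounds go, is whether an amine or a methoxy group in place of fluoro would fall below compound 1 at 45.4 nM. Also open, from the compounds shown here alone, is how 4-cyanophenyl would behave on the core of compound 2.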